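This account rests on a few compounds, and the source may have more. Where it says the series, first, only, none or still open, it means among the compounds named here.

Measured compounds:
Compound 1, `COc1cc(/C=N/Nc2nc(-c3ccc(C(F)(F)F)cc3)cs2)c(Br)c(Br)c1OC`, gives in a functional assay on Caco-2 cells (Homo sapiens) for inhibition, read by MTT assay, with a stated time of 48 h (a lower number here means a stronger inhibitor, a higher number a weaker inhibitor), only a limit, > 100000 nM.
Compound 2, `COc1cc(/C=N/Nc2nc(-c3ccccc3)cs2)c(Br)c(Br)c1OC`, gives 26500 nM.
Compound 3, `COc1cc(/C=N/Nc2nc(-c3ccc(C(F)(F)F)cc3)cs2)cc(Br)c1OC`, gives 65900 nM.

The value of compound 1 is a limit of the assay and not a number: the limit of > 100000 nM in this assay, at which 1 of the 3 values shown sits. The change hydrogen in place of trifluoromethyl on an aromatic carbon brought an at least 3.7-fold lower number from compound 1 to compound 2 (0.57 log units; beyond the scatter). The cores of compound 1 and compound 3 differ by hydrogen in place of bromo on an aromatic carbon, which brought an at least 1.5-fold lower number from compound 1 to compound 3 (0.18 log units; that floor lies within the scatter). Compound 3 stands at the higher of the two numbers, with compound 2 nearest.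

Compound 4, `COc1cc(/C=N/Nc2nc(-c3ccccc3)cs2)cc(Br)c1OC`, is not yet measured. It differs from compound 3 by hydrogen in place of trifluoromethyl on an aromatic carbon, the same change as between compound 1 and compound 2. In this assay a step of a 3.9-fold lower number from compound 3 to compound 4 (0.59 log units; beyond the scatter) is expected, resting on an at least 3.7-fold lower number from compound 1 to compound 2 (0.57 log units; beyond the scatter), whose floor is set by a limit. Compound 4 is therefore estimated at 17000 nM, in the range 6000 nM to 45000 nM.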

Compound 4, half-maximal inhibitory concentration: 64200 nM
Estimate against measurement, compound 4: 3.8-fold (0.58 log units) below; measured number outside the range, above it.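

In this assay, hydrogen in place of trifluoromethyl brought a 1.0-fold lower number from compound 3 to compound 4 (0.01 log units; within the scatter), so the step seen on the core of compound 1 did not carry over to the core of compound 3: the same change on two cores in this assay, an at least 3.7-fold lower number (0.57 log units; beyond the scatter) from compound 1 to compound 2 and a 1.0-fold lower number (0.01 log units; within the scatter) from compound 3 to compound 4, at least 3.6-fold (0.56 log units) apart, beyond the scatter of two such steps. Hydrogen in place of bromo brought a 2.4-fold higher number from compound 2 to compound 4 (0.38 log units; beyond the scatter), and this step did not carry over from one core to the other either: the same change on two cores in this assay, an at least 1.5-fold lower number (0.18 log units; that floor lies within the scatter) from compound 1 to compound 3 and a 2.4-fold higher number (0.38 log units; beyond the scatter) from compound 2 to compound 4, at least 3.6-fold (0.56 log units) apart, beyond the scatter of two such steps. Compound 1 holds a limit of the assay and not a number, so the true size of both gaps stays unknown, and these four compounds show that the steps depend on the core, not why: the limit of > 100000 nM in this assay, at which 1 of the 4 values shown sits.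

Open, on these data alone, is whether a nitrile or a carboxylic acid in place of trifluoromethyl would give the same step on both cores. Also open, as far as these compounds go, is whether an amine in place of bromo would depend on the core in the same way.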